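The compounds below may be only part of what the source reports. "The series", "measured", "known", "first", "only" and "open" are said of these compounds alone.

Measured so far in an ADME assay on THP-1 cells (Homo sapiens) for cytotoxicity, read by MTT assay, with a stated time of 72 h; a higher number here means a weaker inhibitor, a lower number a stronger inhibitor
compound 1 `COc1ccc(/C=C/C(=O)c2c(O)c3ccccc3n(Cc3ccccc3)c2=O)cc1OC` gives 28700 nM
compound 2 `COc1cccc(/C=C/C(=O)c2c(O)c3ccccc3[nH]c2=O)c1` gives 38500 nM

Within the data shown here, these are the only two numbers available. They lie within the usual scatter of repeated measurements of each other, so compound 1 cannot be ranked against compound 2 on this evidence.

Compound 3 `Cc1ccccc1/C=C/C(=O)c1c(O)c2ccccc2n(Cc2ccccc2)c1=O` keeps the core of compound 1 and differs from it in one place, where 2-methylphenyl stands in place of 3,4-dimethoxyphenyl on a double-bonded chain carbon bound to a double-bonded chain carbon (2-methylphenyl in place of 3,4-dimethoxyphenyl on a double-bonded chain carbon bound to a double-bonded chain carbon). Among the measured compounds shown here, the data hold no measured step for a change of this kind, so its size has to be judged with little support. For the measured compounds named here, the one guide is the pair of values: compound 1 at 28700 nM and compound 2 at 38500 nM stay within the scatter of each other, so no step beyond the scatter is expected in this assay in either direction. The estimate is a small one (a 1.1-fold lower number from compound 1 to compound 3 (0.06 log units; within the scatter)), an expected change that stays within the scatter. Compound 3 is expected at 25000 nM (estimated range 10000 nM to 60000 nM).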

Compound 3, half-maximal inhibitory concentration: 45700 nM
Beside the measured number, compound 3's estimate is 1.8-fold (0.26 log units) below it; the measured number falls inside the stated range.
By their numbers in this assay, from the lowest: compounds 1, 2 and 3 (each within the scatter of the next).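

Among these compounds, this is the first step that changes only one place: in this assay, putting 2-methylphenyl in place of 3,4-dimethoxyphenyl on a double-bonded chain carbon bound to a double-bonded chain carbon gives a 1.6-fold higher number from compound 1 to compound 3 (0.20 log units; within the scatter). The swap replaces a group of 10 heavy atoms and 2 hydrogen-bond acceptors with one of 7 heavy atoms and 0 hydrogen-bond acceptors, yet this pair shows no difference that can be told from the scatter, so neither group can be ranked above the other at this place. No measurement available here offers an explanation for this result.

This single pair leaves open whether a different kind of group at this place, such as an amine or a carboxylic acid on the aromatic ring, would produce a step beyond the scatter. Compound 2 differs from both compound 1 and compound 3 in more than one place, so it cannot show what any single change does on its own.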